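A few compounds are considered here, and "the series" means these few. Any claim that something is new, unique, unknown or untested is made for them only; others in the source may bear on it.

Measured compounds:
- compound 1, `Clc1ccc(OC[C@]23C[C@H]2CCN3)cn1`, 341 nM
- compound 2, `c1cncc(OC[C@]23C[C@H]2CCN3)c1`, 242 nM

Both compounds share the same core and differ only in one substituent on the six-membered aromatic ring. In an assay on CHO-K1 cells for displacement of a labelled ligand from Neuronal acetylcholine receptor; alpha4/beta2 (Homo sapiens), read by scintillation counting (on this read-out lower numbers stand for stronger inhibition and higher numbers for weaker inhibition), compound 2 gives the lowest of the two numbers, but its distance to compound 1 is small: the step of a 1.4-fold lower number from compound 1 to compound 2 (0.15 log units; within the scatter) is within the scatter, so the two compounds cannot be told apart on this read-out.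

Compound 3, `Clc1cncc(OC[C@]23C[C@H]2CCN3)c1`, has not yet been measured. It differs from compound 2 by chloro in place of hydrogen on an aromatic carbon, on an aromatic carbon of a six-membered aromatic ring with one nitrogen, two atoms from the ring nitrogen and meta to a group of eight heavy atoms. Among the measured compounds shown here, the only measured step that bears on this change is the removal of chloro from another carbon of the same ring, a 1.4-fold lower number from compound 1 to compound 2 (0.15 log units; within the scatter), which stayed within the scatter. Adding chloro back at a different carbon is therefore expected to move the number by no more than the scatter, with no clear direction.

For compound 3 the estimate in this assay is 260 nM, with a range from 110 nM to 620 nM, corresponding to an expected step of a 1.1-fold higher number from compound 2 to compound 3 (0.03 log units; within the scatter).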

Compound 3, inhibition constant: 827 nM
The estimate for compound 3 lay 3.2-fold (0.50 log units) below the measured number; measured number outside the range, above it.
By their numbers in this assay, from the lowest: compounds 2 and 1 (each within the scatter of the next); then compound 3.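

In this assay, chloro on this carbon, two atoms from the ring nitrogen and meta to a group of 8 heavy atoms, does change the number: a 3.4-fold higher number from compound 2 to compound 3 (0.53 log units; beyond the scatter), a modest step, but one beyond the scatter. The earlier pair could not show this, since chloro on another carbon of the same ring left compound 1 within the scatter of compound 2, so the effect of adding chloro to this ring depends on which carbon carries it. Nothing measured here explains why the two carbons differ.

Among the compounds shown, chloro is the only group on this carbon, so it remains open whether the higher number is specific to chloro or would follow from any group placed here. Compounds carrying fluoro, methyl or methoxy on the same carbon would help separate these two readings, and would show how much room for change this position offers on the shared core.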